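From a Bromo Chain to a Hydroxy Chain

This account rests on a few compounds, and the source may have more. Where it says the series, first, only, none or still open, it means among the compounds named here.

- compound 1 `Brc1ccc(Oc2cc(Br)cc(Br)c2OCCCCCN2CCN(c3ccccc3)CC2)c(Br)c1` gives 41.6 ug/mL
- compound 2 `OCCCOc1c(Br)cc(Br)cc1Oc1ccc(Br)cc1Br` gives 29.9 ug/mL
- compound 3 `BrCCCCCOc1c(Br)cc(Br)cc1Oc1ccc(Br)cc1Br` gives 25.7 ug/mL

These three compounds were tested in a functional assay on HL-60 cells (Homo sapiens) for cytotoxicity, read by MTT assay, with a stated time of 24 h (a higher number here means a weaker inhibitor, a lower number a stronger inhibitor), and share one core. Compound 3 at 25.7 ug/mL lies within the usual scatter of both compound 2 and compound 1, so the three values cannot be told apart.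

The next compound to consider is compound 4 (`OCCOc1c(Br)cc(Br)cc1Oc1ccc(Br)cc1Br`). It differs from compound 3 by having hydroxy in place of 3-bromopropyl on a saturated chain carbon, two bonds along the chain from an oxygen on an aromatic ring.

Going by the values given here, the one measured step that bears on this is a 1.2-fold lower number from compound 2 to compound 3 (0.07 log units; within the scatter), an exchange involving hydroxy and 2-bromoethyl that stayed within the scatter. Compound 2, which also carries hydroxy on its chain, gives 29.9 ug/mL and so anchors the expectation. Among the compounds with values here, no measured pair isolates chain length alone, which leaves some uncertainty. Taken back the other way, that small step suggests little movement, so the expected step is a 1.2-fold higher number from compound 3 to compound 4 (0.08 log units; within the scatter) and nothing beyond the scatter is anticipated. In this assay the estimated value for compound 4 is 31 ug/mL (expected range 17 ug/mL to 55 ug/mL).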

Compound 4, half-maximal inhibitory concentration: 28.2 ug/mL
Beside the measured number, compound 4's estimate is 1.1-fold (0.04 log units) above it; measured number inside the range.
By their numbers in this assay, from the lowest: compounds 3, 4, 2 and 1 (each within the scatter of the next).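

In this assay, the step of a 1.1-fold higher number from compound 3 to compound 4 (0.04 log units; within the scatter) stays within the scatter, even though 3-bromopropyl, with 4 heavy atoms and 0 hydrogen-bond donors, gives way to hydroxy, with 1 heavy atom and 1 hydrogen-bond donor. This shows that a large change in the group on this saturated chain carbon, two bonds along the chain from an oxygen on an aromatic ring, need not move the number beyond the scatter. Going by these compounds alone, the step of a 1.1-fold lower number from compound 2 to compound 4 (0.03 log units; within the scatter) adds the first pair that isolates chain length, since both compounds carry hydroxy and differ only by hydroxy in place of hydroxymethyl, and this change also stays within the scatter.

The compounds shown leave open whether a group of another kind here, such as a carboxylic acid, or a much longer chain ending in hydroxy, would give a number beyond the scatter of these values, and the flat result says nothing about the reason for it. No measurement is available to explain why these changes leave the number within the scatter.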